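The compounds below may be only part of what the source reports. "The series", "measured", "known", "first", "only" and "open" are said of these compounds alone.

Measured so far:
compound 1 `CC(=O)N1CCN(S(=O)(=O)c2ccc(F)cc2)CC1` — 0.01 mg/kg
compound 2 `CCC(=O)N1CCCC(NS(=O)(=O)c2ccc(F)cc2)C1` — 10 mg/kg

The study rests on two measured compounds. In a functional assay on the whole organism with Mus musculus as the target, with a stated time of 30 min (on this read-out lower numbers stand for an effect already at smaller amounts and higher numbers for an effect only at larger amounts of compound), compound 1 gives 0.01 mg/kg. Compound 2, which carries a different core, gives in this assay 10 mg/kg. Of the two numbers, compound 2 stands at the higher one, and the gap to compound 1 is far beyond the usual scatter, so compound 2 shows its effect only at a clearly larger amount than compound 1. Among the compounds with values here, no single-change step between measured compounds is available, so the size of any change cannot be read from the data directly.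

Compound 3 `CC(=O)N1CCCC(NS(=O)(=O)c2ccc(F)cc2)C1` has not yet been measured. It keeps the core of compound 2 and differs from it in one place: hydrogen in place of methyl on a saturated chain carbon bound to a carbonyl carbon The step thus reads propanoyl to acetyl. With only compound 2 as a direct anchor, a small step is expected, in either direction or none beyond the scatter. Compound 3 is estimated at 5 mg/kg, with a range from 1 mg/kg to 30 mg/kg. The expected step of a 2.0-fold lower number from compound 2 to compound 3 (0.30 log units; within the scatter) is therefore modest and well inside what such a change could plausibly give.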

Compound 3, minimum effective dose: 1 mg/kg
Beside the measured number, compound 3's estimate is 5.0-fold (0.70 log units) above it; the range from low to high includes it.
By their numbers in this assay, from the lowest: compound 1; then compound 3; then compound 2.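

This is the first single-change step among the compounds shown, and it shows that the place on a saturated chain carbon bound to a carbonyl carbon is not a silent one: in this assay, going from propanoyl to acetyl gives a 10-fold lower number from compound 2 to compound 3 (1.00 log units; beyond the scatter) and so lies beyond the usual scatter. The group that leaves is only a methyl, with no ring, no hydrogen-bond donor or acceptor and no net charge, and hydrogen enters in its place, so even this small exchange on the core of compound 2 moves the minimum effective dose towards smaller amounts. The data hold no measurement that explains why the shorter chain goes with the lower number.

As far as these compounds go, one step in one direction cannot show whether the trend continues, so it stays open whether a longer chain such as butanoyl, or an amine or a carboxylic acid carried on this chain, would move the number further, reverse it or leave it unchanged. From the compounds shown here alone, it also stays open whether the same exchange would give a step of similar size on the core of compound 1, which already carries an acetyl group.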